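The compounds below may be only part of what the source reports. "The series", "measured", "known", "first", "only" and "open" are said of these compounds alone.

Compound 1 `Nc1ccccc1NC(=O)c1ccc(COc2ccc([N+](=O)[O-])cc2)cc1` sits at the edge of what the series shows: in a functional assay on HepG2 cells (Homo sapiens) for antiproliferative activity, read by CCK-8 assay, with a stated time of 72 h (a lower number here means a stronger inhibitor, a higher number a weaker inhibitor), compound 1 gives > 32000 nM, which is a limit of the assay and not a number (the limit of > 32000 nM in this assay, at which 1 of the 2 values shown sits). Compound 2 `O=C(/C=C/c1ccc(CN2CCc3ccccc32)cc1)NO`, the second measured member, gives 14900 nM in this assay. Compound 3 `CCCc1ccc(OCc2ccc(C(=O)Nc3ccccc3N)cc2)cc1` still awaits measurement in this assay. Its change from compound 1 reads (propyl in place of nitro on an aromatic carbon). Going by the values given here, no measured step of this kind exists in the set, so the size expected for the step of an at least 1.6-fold lower number from compound 1 to compound 3 (0.20 log units; that floor lies within the scatter) is modest and need not exceed the scatter. Compound 3 is expected to give about 20000 nM, within 5000 nM to 60000 nM.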

Compound 3, half-maximal inhibitory concentration: 4750 nM
Compound 3: middle estimate off by 4.2-fold (0.62 log units), on the high side; measured number below the stated range.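

Going by these compounds alone, putting propyl in place of nitro on this aromatic carbon, para to a large group, gives the first measured step at this position in this assay: an at least 6.7-fold lower number from compound 1 to compound 3 (0.82 log units; beyond the scatter). The position therefore responds to the group it carries, and compound 3 gives 4750 nM, a number and not a limit. The true size of the step stays unknown because compound 1 stands at a limit of the assay: the limit of > 32000 nM in this assay, at which 1 of the 3 values shown sits.

From the compounds shown here alone, whether the shift follows from losing nitro or from gaining propyl stays open. So does how a butyl chain, an amine or a carboxylic acid would read at this carbon.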